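The compounds below may be only part of what the source reports. "The series", "measured", "known", "first", "only" and "open" are said of these compounds alone.

Compound 1 `O=C1NC(O)(CCn2cc(C3=CCCCC3)nn2)C(OCc2ccccc2)=C1OCc1ccccc1` gives 67200 nM in a functional assay on PC-3 cells (Homo sapiens) for antiproliferative activity, read by MTT assay, with a stated time of 24 h; on this read-out higher numbers stand for weaker inhibition and lower numbers for stronger inhibition.
Compound 2 `CC(C)(C)c1ccc(-c2cn(CCC3(O)NC(=O)C(OCc4ccccc4)=C3OCc3ccccc3)nn2)cc1` gives 43000 nM in this assay.

Of the two numbers shown, compound 2 carries the smaller one, but the single step leading to it, a 1.6-fold lower number from compound 1 to compound 2 (0.19 log units; within the scatter), lies within the scatter, so nothing separates the two compounds. Compound 3 `O=C1NC(O)(CCn2cc(Cc3ccccc3)nn2)C(OCc2ccccc2)=C1OCc1ccccc1` differs from compound 2 by benzyl in place of 4-(tert-butyl)phenyl on an aromatic carbon. Among the compounds with values here, the only measured step that bears on this position, a 1.6-fold lower number from compound 1 to compound 2 (0.19 log units; within the scatter), swapped one group on that same aromatic carbon for another and stayed within the scatter. On that evidence a further swap of the group at this carbon is not expected to move the number beyond the scatter in either direction. The expected step is therefore small: a 1.2-fold higher number from compound 2 to compound 3 (0.07 log units; within the scatter). Compound 3 is estimated at 50000 nM, with a range from 25000 nM to 100000 nM.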

Compound 3, half-maximal inhibitory concentration: > 100000 nM
Compound 3: only a limit was reported; the forecaster's own chance of this, stated with the estimate: 10%; middle value at least 2.0-fold (0.30 log units) from the limit.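

Changing the group on this aromatic carbon can matter after all: there is an at least 2.3-fold higher number from compound 2 to compound 3 (0.36 log units; beyond the scatter), even though benzyl and 4-(tert-butyl)phenyl each carry one six-membered aromatic ring of carbon only. Measured against cyclohex-1-en-1-yl, the same benzyl gives a less clear result, with an at least 1.4-fold higher number from compound 1 to compound 3 (0.17 log units; that floor lies within the scatter), so this comparison does not separate the two groups. Compound 3 has only a limit of the assay rather than a number, so both steps give minimum sizes: the limit of > 100000 nM in this assay, at which 1 of the 3 values shown sits.

On these data alone, the true size of the change for compound 3 stays unknown. Also open, as far as these compounds go, is whether a plain phenyl, or a phenyl carrying an amine or a carboxylic acid in place of tert-butyl, would give a number like that of compound 2.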